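A Chloro Swap at the Assay Limit

The compounds below may be only part of what the source reports. "The series", "measured", "known", "first", "only" and "open" are said of these compounds alone.

Of the compounds shown here, three have been tested in a functional assay on HepG2 cells (Homo sapiens) for cytotoxicity, read by CCK-8 assay; a higher number here means a weaker inhibitor, a lower number a stronger inhibitor. Compound 1 (`COc1ccc(NC(=O)c2ncc(-c3cc(OC)c(OC)c(OC)c3)o2)cc1`) gives > 30000 nM as a limit. Compound 2 (`O=C(Nc1ccc(O)cc1)c1ncc(-c2ccc(F)cc2)o1`) gives > 30000 nM as a limit. Compound 3 (`COc1ccc(NC(=O)c2ncc(-c3ccccc3)o2)cc1`) gives > 30000 nM as a limit, so it has no number of its own. For the measured compounds named here, it stands with the other two at the limit of > 30000 nM in this assay, at which 3 of the 3 values shown sit, and no measured step separates them. Compound 4 (`O=C(Nc1ccc(Cl)cc1)c1ncc(-c2ccccc2)o1`) has chloro in place of methoxy on an aromatic carbon. The expected a number no higher from compound 3 to compound 4 (the limit leaves the size open) is none beyond the scatter, with neither direction favoured. For compound 4 the estimated value is 30000 nM within an expected range of 12000 nM to 60000 nM in this test, and another limit may well be reported.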

Compound 4, half-maximal inhibitory concentration: > 30000 nM
Compound 4 was reported as a limit; the forecaster's own chance of this, stated with the estimate: 70%; the middle value lies on the limit itself.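

Compound 3 and compound 4 both stand only as limits in this assay, so no step can be read between them: the limit of > 30000 nM in this assay, at which 4 of the 4 values shown sit.

The compounds shown leave open whether any of them has a measurable value in this assay.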